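This account rests on a few compounds, and the source may have more. Where it says the series, first, only, none or still open, it means among the compounds named here.

Two pairs of compounds share one structural change. Compound 1 `COc1ccc(O)c(CSc2ccccc2)c1` and compound 2 `COc1ccc(O)c(CSc2ccccc2CO)c1` are built on one core, and compound 2 differs from compound 1 only as hydroxymethyl in place of hydrogen on an aromatic carbon. Measured in a functional assay for inhibition, with Homo sapiens as the target (on this read-out lower numbers stand for stronger inhibition and higher numbers for weaker inhibition), compound 1 gives 590 nM, while compound 2 gives 8700 nM. That change produced a 15-fold higher number from compound 1 to compound 2 (1.17 log units; beyond the scatter), a step well outside the usual scatter.

Compound 3 `Oc1cc2c(cc1CNc1ccccc1)OCC2` rests on a different core; the difference between the two cores is not broken down here. In this assay compound 3 gives 490 nM, a number within the scatter of compound 1 and far from compound 2. Compound 4 `OCc1ccccc1NCc1cc2c(cc1O)CCO2` has not yet been measured. It differs from compound 3 as hydroxymethyl in place of hydrogen on an aromatic carbon, the same change already seen once, at the same kind of place.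

Among the compounds with values here, because the only earlier instance of this change gave a 15-fold higher number from compound 1 to compound 2 (1.17 log units; beyond the scatter), a step of similar direction, though possibly smaller on a new core, is expected here. The expected step is an 11-fold higher number from compound 3 to compound 4 (1.05 log units; beyond the scatter). Compound 4 is therefore estimated at about 5500 nM, most likely between 1500 nM and 20000 nM.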

Compound 4, half-maximal inhibitory concentration in the Homo sapiens assay: 11000 nM
Beside the measured number, compound 4's estimate is 2.0-fold (0.30 log units) below it, within the range that was stated.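

In the Homo sapiens assay, hydroxymethyl in place of hydrogen on an aromatic carbon gave a 22-fold higher number from compound 3 to compound 4 (1.35 log units; beyond the scatter), so inhibition weakened on this second core as it did on the first, and the two steps agree in size: the same change on two cores in the Homo sapiens assay, a 15-fold higher number (1.17 log units; beyond the scatter) from compound 1 to compound 2 and a 22-fold higher number (1.35 log units; beyond the scatter) from compound 3 to compound 4, 1.5-fold (0.18 log units) apart, within the scatter of two such steps. In a physicochemical assay for lipophilicity (a higher number here means a more lipophilic compound, a lower number a more polar compound), compound 3 gives 2.9 and compound 4 gives 1.9, so the same change also left compound 4 more polar than compound 3: the measured partition coefficient of compound 3, 2.9, and of compound 4, 1.9, a number 1.00 log units lower (beyond the scatter). Within the data shown here, still, the comparison rests on only two pairs of compounds, so it sets no rule for other cores, and it does not show why the number in the Homo sapiens assay rises with this change.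

From the compounds shown here alone, it remains open whether another group at the same place, such as a methoxymethyl, an amine or a carboxylic acid, would give a smaller or larger step on either core. Going by these compounds, it also remains open whether hydroxymethyl would give a similar step at another place on the same ring.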